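This account rests on a few compounds, and the source may have more. Where it says the series, first, only, none or still open, it means among the compounds named here.

Measured so far:
compound 1 `CC1(C)SC(c2ccccc2N)=NN1C(=O)c1ccccc1` — 39.8%
compound 2 `COc1ccc(N)c(C2=NN(C(=O)C3CCCC3)C(C)(C)S2)c1` — 65%
compound 3 `COc1ccc(N)c(C2=NN(C(=O)c3ccccc3)C(C)(C)S2)c1` — 0%

In an assay on isolated protein for inhibition of Nitric oxide synthase, inducible (Homo sapiens), read by scintillation counting, with a stated time of 30 min, tested at 50 uM (on this read-out lower numbers stand for less inhibition and higher numbers for more inhibition at the one concentration tested (going by the name of the read-out)), compound 1 stands second of the three numbers: compound 2 is higher, and the step of a number 39.8 percentage points lower from compound 1 to compound 3 (beyond the scatter) shows that adding a methoxy group takes the inhibition away entirely.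

Compound 4 `CC1(C)SC(c2ccccc2N)=NN1C(=O)C1CCCCC1` differs from compound 1 in one place: cyclohexyl in place of phenyl on a carbonyl carbon. The step that bears on it is a number 65 percentage points lower from compound 2 to compound 3 (beyond the scatter), where swapping a non-aromatic ring for phenyl on the carbonyl carbon cut the inhibition sharply; read the other way, a non-aromatic ring in place of phenyl raised it a great deal, although that comparison sits in the methoxy-bearing pair and the ring there was a cyclopentyl rather than a cyclohexyl. A rise of similar size in this assay is therefore expected for compound 4, estimated as a number 25.2 percentage points higher from compound 1 to compound 4 (beyond the scatter). Compound 4 is expected to give about 65%, within a range from 40% to 90%.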

Compound 4, a percentage reported as inhibition, at one concentration (the size of the read-out at that concentration, not a potency): 28%
The estimate for compound 4 lay 37 percentage points above the measured number; measured number outside the range, below it.
By their numbers in this assay, from the lowest: compound 3; then compound 4; then compound 1; then compound 2.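

In this assay, cyclohexyl in place of phenyl on a carbonyl carbon gives a number 11.8 percentage points lower from compound 1 to compound 4 (beyond the scatter), so on the core without the methoxy group this non-aromatic ring does not raise the inhibition. With the methoxy group present, phenyl in place of cyclopentyl gives a number 65 percentage points lower from compound 2 to compound 3 (beyond the scatter), which means that phenyl reads lower than the non-aromatic ring in that pair but higher in this one, and the preference at this position does not carry over from one pair to the other. No measurement available here accounts for this difference between the pairs.

The two pairs differ in both the methoxy group and the size of the non-aromatic ring, so the compounds shown leave open which of the two separates their results. On these data alone, how an open chain such as butyl, or a pyridine ring, would read on the same carbonyl carbon also remains open.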